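Adding One Methyl to a Cytotoxic Compound

This account rests on a few compounds, and the source may have more. Where it says the series, first, only, none or still open, it means among the compounds named here.

Compound 1 `CC(=O)Oc1cc(C)c(OC(C)=O)c2c1CC=C(CCC=C(C)C)C2` gives 2900 nM
Compound 2 `CC(C)=CCCC1=CCC2=C(C1)C(=O)C=CC2=O` gives 1000 nM
Compound 3 `CC(C)=CCCc1ccc2c(c1)C(=O)C=CC2=O` gives 400 nM

All three numbers come from a functional assay on P388 cells (Mus musculus) for cytotoxicity (on this read-out lower numbers stand for stronger inhibition and higher numbers for weaker inhibition), and can be compared directly. Compound 3 stands lowest, and its gaps to compound 2 and compound 1 both lie beyond the scatter. Compound 4 `CC(C)=CCCc1ccc2c(c1)C(=O)C(C)=CC2=O` has not yet been measured. It differs from compound 3 in one place, with methyl in place of hydrogen on a double-bonded ring carbon. Within the data shown here, no measured pair shows this change, so the expectation is loose. For so small an edit, no step beyond the scatter is expected in this assay (estimated as a 1.3-fold higher number from compound 3 to compound 4 (0.10 log units; within the scatter)). Compound 4 is estimated at 500 nM with 150 nM to 1500 nM as the expected range.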

Compound 4, half-maximal inhibitory concentration: 3900 nM
Compound 4: the middle estimate sits 7.8-fold (0.89 log units) below what was measured; measured number above the stated range.
By their numbers in this assay, from the lowest: compound 3; then compound 2; then compounds 1 and 4 (each within the scatter of the next).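

Within this assay the swap of hydrogen for methyl on a double-bonded ring carbon gives a 9.8-fold higher number from compound 3 to compound 4 (0.99 log units; beyond the scatter) and so weakens inhibition clearly. This is the first one-place comparison among these compounds, and it shows that this ring carbon is sensitive: even the addition of one heavy atom moves the number beyond the scatter. Nothing available here gives a reason for this rise.

As far as these compounds go, whether an ethyl group, a chlorine atom or an amine on this same carbon would move the number as far stays open. So does whether methyl would have the same effect at this carbon in the core of compound 2.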